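Methyl on the chain carbon: compound 3 to compound 4

The compounds below may be only part of what the source reports. "The series", "measured", "known", "first", "only" and "open" are said of these compounds alone.

Among the measured compounds shown here, compound 3 `O=C(O)COc1ccc(NC(=O)COc2cccc(C(F)(F)F)c2)cc1F` gives 11.4% in a functional assay on CHO cells for agonist activity at Free fatty acid receptor 1 (Homo sapiens), read by FLIPR, tested at 100 nM (on this read-out higher numbers stand for a stronger effect at the one concentration tested and lower numbers for a weaker effect), the lowest of the three numbers so far, beyond the scatter below both others. For the measured compounds named here, compound 1 `CC(Oc1ccccc1)C(=O)Nc1ccc(OCC(=O)O)c(F)c1` gives 35.7% and compound 2 `CC(Oc1cccc(C(C)(C)C)c1)C(=O)Nc1ccc(OCC(=O)O)c(F)c1` gives 32.8% in this assay; the one measured step, a number 2.9 percentage points lower from compound 1 to compound 2 (within the scatter), concerns an aromatic substituent, not the chain. Compound 4 `CC(Oc1cccc(C(F)(F)F)c1)C(=O)Nc1ccc(OCC(=O)O)c(F)c1` carries methyl in place of hydrogen on a saturated chain carbon bound to a carbonyl carbon and an oxygen on an aromatic ring. Going by the values given here, no measured pair isolates this change: compound 1 and compound 2 both carry the methyl and compound 3 does not, but compound 3 also differs from them at the aromatic ring. Since both methyl-bearing compounds sit beyond the scatter above compound 3, a rise is expected, of uncertain size. Compound 4 is estimated at 27% (range 10% to 44%). The expected step is a number 15.6 percentage points higher from compound 3 to compound 4 (beyond the scatter).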

Compound 4, a percentage reported as activity, at one concentration (the size of the read-out at that concentration, not a potency) in the Free fatty acid receptor 1 assay: 12.7%
Beside the measured number, compound 4's estimate is 14.3 percentage points above it; measured number inside the range.
By their numbers in the Free fatty acid receptor 1 assay, from the lowest: compounds 3 and 4 (each within the scatter of the next); then compounds 2 and 1 (each within the scatter of the next).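

In the Free fatty acid receptor 1 assay compound 3 gives 11.4% and compound 4 gives 12.7%; the methyl gives a number 1.3 percentage points higher from compound 3 to compound 4 (within the scatter), so with trifluoromethyl on the aromatic ring this chain position shows no effect of the change. With the methyl held, the aromatic substituent carries the difference: a number 20.1 percentage points lower from compound 2 to compound 4 (beyond the scatter) for trifluoromethyl in place of tert-butyl, and a number 23 percentage points lower from compound 1 to compound 4 (beyond the scatter) for trifluoromethyl in place of hydrogen. No available evidence accounts for these results. In a physicochemical assay for lipophilicity, using the shake flask method, at pH 7.4 (on this read-out higher numbers stand for higher lipophilicity and lower numbers for lower lipophilicity), compound 3 is recorded as "not determined" (no result reported) and compound 4 as "not determined" (no result reported), so this read-out allows no comparison of the two.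

Going by these compounds, whether the methyl stays without effect alongside hydrogen or tert-butyl on the aromatic ring remains open. So does the outcome with an ethyl group on the chain carbon, or with chlorine or methoxy in place of trifluoromethyl.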